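Chloro Added to Two Related Cores

The compounds below may be only part of what the source reports. "The series", "measured", "known", "first", "only" and "open" are said of these compounds alone.

Measured so far:
compound 1, `CCCCC(CCO)n1cnc2c(Cl)ncnc21`, > 50000 nM
compound 2, `CCCCC(CCO)n1cnc2c(Cl)nc(Cl)nc21`, 30900 nM
compound 3, `CCCCCCCCCCC(CCO)n1cnc2c(N)ncnc21`, 1200 nM

In a functional assay on SW480 cells (Homo sapiens) for antiproliferative activity, read by MTT assay, with a stated time of 48 h (on this read-out lower numbers stand for stronger inhibition and higher numbers for weaker inhibition), compound 1 gives > 50000 nM, which is a limit of the assay rather than a number (the limit of > 50000 nM in this assay, at which 1 of the 3 values shown sits). Compound 2 gives 30900 nM. Compound 3 gives 1200 nM. The change chloro in place of hydrogen on an aromatic carbon produced an at least 1.6-fold lower number from compound 1 to compound 2 (0.20 log units; that floor lies within the scatter). The difference between the core of compound 1 and that of compound 3 is not broken down here.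

Compound 4, `CCCCCCCCCCC(CCO)n1cnc2c(N)nc(Cl)nc21`, is not yet measured. It differs from compound 3 by chloro in place of hydrogen on an aromatic carbon. This is the same kind of change as between compound 1 and compound 2, but the surroundings differ: in compound 1 the site is meta to a chloro group, in compound 3 it is meta to an amino group.

Resting on an at least 1.6-fold lower number from compound 1 to compound 2 (0.20 log units; that floor lies within the scatter), the expected step is a 1.5-fold lower number from compound 3 to compound 4 (0.18 log units; within the scatter). Compound 4 is estimated at 800 nM, between 300 nM and 2500 nM.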

Compound 4, half-maximal inhibitory concentration: 13100 nM
Beside the measured number, compound 4's estimate is 16-fold (1.21 log units) below it; the measured number lies above the stated range.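

In this assay, chloro in place of hydrogen on an aromatic carbon gave an 11-fold higher number from compound 3 to compound 4 (1.04 log units; beyond the scatter), a large step toward weaker inhibition. The result of this change on one core therefore did not predict its result on the other: the same change on two cores in this assay, an at least 1.6-fold lower number (0.20 log units; that floor lies within the scatter) from compound 1 to compound 2 and an 11-fold higher number (1.04 log units; beyond the scatter) from compound 3 to compound 4, at least 17-fold (1.24 log units) apart, beyond the scatter of two such steps

This does not show what separates the two cases, since compound 1 and compound 3 differ both in the chain and in carrying chloro or amino on the ring, and these compounds cannot tell those two differences apart.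

Still open, going by these compounds, is how a bromo or a methyl group would behave in place of this chloro. Also open, on these data alone, is how the amino group would behave on the shorter chain of compound 1.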